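The source may report more compounds than this note shows. Statements on the series, on what has been measured and on what is new or still open speak of the compounds shown alone.

Of the compounds shown here, three that share one core have been measured in a functional assay on Caco-2 cells (Homo sapiens) for antiproliferative activity, read by MTT assay, with a stated time of 48 h; a lower number here means a stronger inhibitor, a higher number a weaker inhibitor. Compound 1 `CCN(CC)CCNC(=O)c1ccc(C(CC)(CC)c2ccc(OCCC(O)(CC)CC)c(C)c2)n1CC` gives 1630 nM in this assay. Compound 2 `CCn1c(C(=O)NCCN)ccc1C(CC)(CC)c1ccc(OCCC(O)(CC)CC)c(C)c1` gives 1740 nM, the second highest number of the three; its nearest neighbour is compound 1, its furthest compound 3. Compound 3 `CCOC(=O)CN(C)C(=O)c1ccc(C(CC)(CC)c2ccc(OCCC(O)(CC)CC)c(C)c2)n1CC` gives 30300 nM. The step between the two amine-bearing compounds is small: a 1.1-fold higher number from compound 1 to compound 2 (0.03 log units; within the scatter). By contrast, swapping the amine-bearing chain on the carbonyl carbon for an ester-bearing group gives a 19-fold higher number from compound 1 to compound 3 (1.27 log units; beyond the scatter) and a 17-fold higher number from compound 2 to compound 3 (1.24 log units; beyond the scatter), both large steps toward weaker inhibition.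

Compound 4 `CCOC(=O)C(CC(=O)OC)NC(=O)c1ccc(C(CC)(CC)c2ccc(OCCC(O)(CC)CC)c(C)c2)n1CC` has not yet been measured. It differs from compound 2 in one place: a group of 11 heavy atoms (7 carbon, 4 oxygen; no ring) in place of a group of 3 heavy atoms (2 carbon, 1 nitrogen; no ring), on an amide-type nitrogen. As in the change from compound 2 to compound 3, the amine-bearing chain is lost and an ester-bearing group takes its place, so the two large measured steps are the ones that bear on it. A step of similar size, toward a higher number, is therefore expected: a 14-fold higher number from compound 2 to compound 4 (1.16 log units; beyond the scatter). Compound 4 is estimated to give about 25000 nM in this assay, with a likely range from 8000 nM to 80000 nM.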

Compound 4, half-maximal inhibitory concentration: 3020 nM
Beside the measured number, compound 4's estimate is 8.3-fold (0.92 log units) above it; measured number outside the range, below it.
By their numbers in this assay, from the lowest: compounds 1, 2 and 4 (each within the scatter of the next); then compound 3.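

In this assay, the amine-bearing chain on the amide-type nitrogen turns out not to be essential in this series: the group that enters holds no nitrogen, yet the change gives a 1.7-fold higher number from compound 2 to compound 4 (0.24 log units; within the scatter) and a 1.9-fold higher number from compound 1 to compound 4 (0.27 log units; within the scatter). Within the data shown here, an ester-bearing group therefore does not by itself carry the large loss that the earlier steps seemed to point to, and the new result instead shows that two such groups can differ sharply, with a 10-fold lower number from compound 3 to compound 4 (1.00 log units; beyond the scatter). One visible difference in that pair is that compound 4 keeps the amide hydrogen, whereas compound 3 has a methyl on that nitrogen, and the two ester-bearing groups also differ in the rest of their atoms.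

Nothing available explains why these two ester-bearing compounds stand so far apart. As far as these compounds go, it remains open whether the methyl alone sets compound 3 apart, which a methyl on the amide nitrogen of compound 4 would test, and whether a carboxylic acid in place of either ester would stay level with the amines.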